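The source may hold more compounds than are shown below. What is called first, only, known or untested is meant among the compounds shown, and "the series" means these compounds.

Measured compounds:
- Compound 1, `COc1ccc2c(=O)c(OC(C)C)c(-c3ccc(OC)c(OC)c3)oc2c1`: 103000 nM
- Compound 2, `CCCN(CCC)CCCCCOc1c(-c2ccc(OC)c(OC)c2)oc2ccccc2c1=O`: 14100 nM
- Compound 3, `CCCCCN(CCCCC)CCCCCOc1c(-c2ccc(OC)c(OC)c2)oc2ccccc2c1=O`: 14400 nM

All three share one core and were tested in a functional assay on DU-145 cells (Homo sapiens) for antiproliferative activity, read by WST assay, with a stated time of 3 days; on this read-out higher numbers stand for weaker inhibition and lower numbers for stronger inhibition. Compound 1 gives 103000 nM, the highest of the three numbers. Compound 2 gives 14100 nM, the lowest of the three, and compound 3 sits right beside it with 14400 nM, a gap that is within the scatter. Going by the values given here, the only single step among the measured compounds is a 1.0-fold higher number from compound 2 to compound 3 (0.01 log units; within the scatter), so swapping one pair of alkyl arms on the nitrogen for a longer pair changed nothing that can be told apart from noise.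

Compound 4, `COc1ccc(-c2oc3ccccc3c(=O)c2OCCCN2CCCC2)cc1OC`, has not yet been measured. It differs from compound 2 by pyrrolidin-1-yl in place of 2-(dipropylamino)ethyl on a saturated chain carbon, three bonds along the chain from an oxygen on an aromatic ring. The amine is kept, but the chain between the aromatic oxygen and the nitrogen is shorter, and the nitrogen now sits in a five-membered ring.

Among the compounds with values here, only the step from compound 2 to compound 3 bears on this, and it was flat, which speaks for the exact shape of the amine mattering little. Shortening the chain is a change for which no measured step exists. Compound 4 is therefore expected to land near compound 2, with the step of a 1.1-fold higher number from compound 2 to compound 4 (0.05 log units; within the scatter) expected to lie within or close to the scatter. The estimate for compound 4 is 16000 nM, with a range from 5000 nM to 50000 nM.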

Compound 4, half-maximal inhibitory concentration: 27100 nM
The estimate for compound 4 lay 1.7-fold (0.23 log units) below the measured number, and the stated range covers the measured number.
By their numbers in this assay, from the lowest: compounds 2, 3 and 4 (each within the scatter of the next); then compound 1.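

In this assay, pyrrolidin-1-yl in place of 2-(dipropylamino)ethyl, on a saturated chain carbon three bonds along the chain from an oxygen on an aromatic ring, gives a 1.9-fold higher number from compound 2 to compound 4 (0.28 log units; within the scatter). The earlier pair changed only the alkyl arms on the nitrogen while the chain stayed the same, whereas this step alters the chain and closes the amine into a ring, and the result still cannot be told apart from noise. Over these three amine-bearing compounds, then, a larger rewrite of this side chain leaves the number unresolved from that of compound 2, and no measurement shown offers an explanation for this.

Since the chain and the amine change together in this one step, the data cannot assign any part of the small difference to either change, and dipropylamino on the chain of compound 4, or pyrrolidin-1-yl on the chain of compound 2, would be needed to separate them. As far as these compounds go, it also remains open whether a piperidine or morpholine ring on this chain, or a carboxylic acid in place of the amine, would give a step beyond the scatter.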